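Branching the Ester Chain in Two Related Thiourea and Urea Cores

A few compounds are considered here, and "the series" means these few. Any claim that something is new, unique, unknown or untested is made for them only; others in the source may bear on it.

Measured compounds:
Compound 1, `CCCOC(=O)C1=C(C)NC(=S)NC1c1ccoc1`: 45%
Compound 2, `CC1=C(C(=O)OCC(C)C)C(c2ccoc2)NC(=S)N1`: 1%
Compound 3, `CCCOC(=O)C1=C(C)N(C)C(=O)NC1c1cccs1`: 1%

In an assay on membranes from HEK293 cells for displacement of a labelled ligand from adenosine receptor A2b (Homo sapiens), read by scintillation counting, with a stated time of 30 min, tested at 1 uM (on this read-out higher numbers stand for more inhibition at the one concentration tested (going by the name of the read-out) and lower numbers for less inhibition), compound 1 gives 45%. Compound 2 carries one change against it, (methyl in place of hydrogen on a saturated chain carbon bound to two saturated chain carbons), and in this assay compound 2 gives 1%, a step of a number 44 percentage points lower from compound 1 to compound 2 (beyond the scatter). Compound 3 has a different core; how its core differs from that of compound 1 is not broken down here. In this assay compound 3 gives 1%, level with compound 2 at the digits shown.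

Compound 4, `CC1=C(C(=O)OCC(C)C)C(c2cccs2)NC(=O)N1C`, has not yet been measured. It stands to compound 3 as compound 2 stands to compound 1: the change is methyl in place of hydrogen on a saturated chain carbon bound to two saturated chain carbons, at the same place on the chain, so it is the same change on a different core. Among the measured compounds shown here, the one measured example of this change, from compound 1 to compound 2, was a large drop. Compound 3 is already at the bottom of the read-out, so there is little room for a further fall; the expected step from compound 3 to compound 4 is no change at the digits printed from compound 3 to compound 4 (within the scatter), resting on the level of compound 3 at 1%. Compound 4 is therefore expected to give about 1%, between -9% and 11%.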

Compound 4, a percentage reported as inhibition, at one concentration (the size of the read-out at that concentration, not a potency): 2%
The estimate for compound 4 lay 1 percentage points below the measured number; the measured number falls inside the stated range.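

In this assay, the change from propoxy to isobutoxy does not give the same result on the two cores: the same change on two cores in this assay, a number 44 percentage points lower (beyond the scatter) from compound 1 to compound 2 and a number 1 percentage points higher (within the scatter) from compound 3 to compound 4, 45 percentage points apart, beyond the scatter of two such steps. The new step is a number 1 percentage points higher from compound 3 to compound 4 (within the scatter), and compound 3 already sits at 1%, close to the bottom of the read-out, which leaves almost no room to see a further loss. The large drop seen on the core of compound 1 therefore does not reappear on the second core, but this does not show that the added methyl leaves the number level on that core, and two pairs of compounds set no general rule for the series.

On these data alone, what the methyl does on the second core remains open, and it could be judged only on a compound of that core that gives a clearly higher number. Also open, as far as these compounds go, is how the core of compound 1 would respond to a longer chain such as butoxy, or to a carboxylic acid in place of the ester.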